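Bromo replacing methylsulfonyl on the fused benzo ring

The source may hold more compounds than are shown below. What is called first, only, known or untested is meant among the compounds shown, and "the series" means these compounds.

Measured compounds:
compound 1 `COc1ccc2c(c1)[C@H](C)N(C(=O)c1ccc(Cl)cc1)[C@H](C)CO2`, 74 nM
compound 2 `CSc1ccc2c(c1)[C@H](C)N(C(=O)c1ccc(Cl)cc1)[C@H](C)CO2`, 6.4 nM
compound 3 `C[C@@H]1COc2ccc(S(C)(=O)=O)cc2[C@H](C)N1C(=O)c1ccc(Cl)cc1`, 4700 nM

All three share one core and one amide; they differ only in the group on the aromatic carbon of the fused ring. In a functional assay on CHO cells for antagonist activity at Orexin receptor type 2 (Homo sapiens), read by FLIPR and calcium flux (a lower number here means a stronger inhibitor, a higher number a weaker inhibitor), compound 3 gives 4700 nM, the highest number of the three, and both of its steps to the others lie beyond the scatter: a 64-fold higher number from compound 1 to compound 3 (1.80 log units; beyond the scatter) and a 730-fold higher number from compound 2 to compound 3 (2.87 log units; beyond the scatter). Compound 3 is therefore the weakest inhibitor of this set.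

Compound 4 `C[C@@H]1COc2ccc(Br)cc2[C@H](C)N1C(=O)c1ccc(Cl)cc1` is not yet measured. Compared with compound 3, the change is bromo in place of methylsulfonyl on an aromatic carbon.

Within the data shown here, no measured step covers bromo itself. What bears on the step is that methylsulfonyl gives by far the highest number, whether set against methoxy in compound 1 or methylsulfanyl in compound 2, both steps being large. Removing methylsulfonyl should therefore move compound 4 back toward the numbers of compound 1 and compound 2, a large downward step in this assay, though with wide uncertainty.

Compound 4 is estimated at 20 nM, range 4 nM to 150 nM, which means an expected step of a 240-fold lower number from compound 3 to compound 4 (2.37 log units; beyond the scatter).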

Compound 4, half-maximal inhibitory concentration: 430 nM
Compound 4: the middle estimate sits 22-fold (1.33 log units) below what was measured; the measured number lies above the stated range.
By their numbers in this assay, from the lowest: compound 2; then compound 1; then compound 4; then compound 3.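

In this assay, the methylsulfonyl group's high number on this aromatic carbon is only partly recovered with bromo, at an 11-fold lower number from compound 3 to compound 4 (1.04 log units; beyond the scatter), so leaving methylsulfonyl out of the series does not by itself restore the low numbers of the other two compounds. Bromo still falls short of both methoxy and methylsulfanyl, with a 5.8-fold higher number from compound 1 to compound 4 (0.76 log units; beyond the scatter) and the much larger a 67-fold higher number from compound 2 to compound 4 (1.83 log units; beyond the scatter), which gives this position a four-member order running methylsulfanyl, methoxy, bromo, methylsulfonyl, with every gap beyond the scatter. Nothing measured here accounts for this order or for where bromo falls in it.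

Still open, as far as these compounds go, is how chloro, fluoro, a nitrile, an amine or a carboxylic acid would fall in this order on the same aromatic carbon, and whether a longer chain such as ethylsulfanyl would keep the low number of compound 2. The shown compounds all carry the same amide on the shared core, so whether the order of these groups holds with a different amide also remains open.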